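Compound 3 to compound 4: exchanging the aryl group

The compounds below may be only part of what the source reports. "The series", "measured", "known", "first", "only" and "open" are said of these compounds alone.

Measured in an ADME assay on MT4 cells (Homo sapiens) for cytotoxicity, read by MTT assay; a lower number here means that less compound is tolerated, a higher number that more compound is tolerated:
- compound 1 `Cc1ccccc1C(=O)N(C(=S)OCCN1C(=O)c2ccccc2C1=O)c1ccc(Cl)cc1`: 21000 nM
- compound 2 `O=C1c2ccccc2C(=O)N1CCOC(=S)N(C(=O)c1ccccc1[N+](=O)[O-])c1ccc(Cl)cc1`: 21000 nM
- compound 3 `O=C1c2ccccc2C(=O)N1CCOC(=S)N(C(=O)c1ccc(C(F)(F)F)cc1)c1ccc(Cl)cc1`: 10000 nM

Compound 3 has the lowest number of the three, at 10000 nM. Compound 4 `O=C1c2ccccc2C(=O)N1CCOC(=S)N(C(=O)c1ccc(F)c(F)c1)c1ccc(Cl)cc1` has not yet been measured. It differs from compound 3 by 3,4-difluorophenyl in place of 4-(trifluoromethyl)phenyl on a carbonyl carbon.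

Two measured steps change the group at this same place: a 2.1-fold lower number from compound 1 to compound 3 (0.32 log units; beyond the scatter), and a 2.1-fold lower number from compound 2 to compound 3 (0.32 log units; beyond the scatter). Both are modest. A third step, no change at the digits printed from compound 1 to compound 2 (within the scatter), also concerns this aromatic group, as nitro in place of methyl on an aromatic carbon. Among the compounds with values here, none of the measured compounds carries 3,4-difluorophenyl, so the direction of the step rests on little evidence.

Since compound 3 is the lowest of the three, with compound 1 at 21000 nM and compound 2 at 21000 nM, a replacement of its 4-(trifluoromethyl)phenyl group is expected to give a small rise at most. The expected result in this assay is an estimated 1.5-fold higher number from compound 3 to compound 4 (0.18 log units; within the scatter), a step that may not exceed the scatter. For compound 4 the estimated value is 15000 nM, with an expected range of 8000 nM to 28000 nM.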

Compound 4, half-maximal cytotoxic concentration: 52000 nM
Beside the measured number, compound 4's estimate is 3.5-fold (0.54 log units) below it; the whole stated range lies below it.
By their numbers in this assay, from the lowest: compound 3; then compounds 1 and 2 (each within the scatter of the next); then compound 4.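

In this assay the group on the carbonyl carbon proves able to move the number further than compounds 1, 2 and 3 showed: exchanging 4-(trifluoromethyl)phenyl for 3,4-difluorophenyl, a loss of only two heavy atoms with no change in hydrogen-bond donors, acceptors or charge, gives a 5.2-fold higher number from compound 3 to compound 4 (0.72 log units; beyond the scatter). Compound 4 also clears the two compounds that were level with each other, with a 2.5-fold higher number from compound 1 to compound 4 (0.39 log units; beyond the scatter) and a 2.5-fold higher number from compound 2 to compound 4 (0.39 log units; beyond the scatter), so 3,4-difluorophenyl gives the highest number of the four, with steps to all the others beyond the scatter. Compounds 3 and 4 both carry fluorine yet stand at opposite ends of the order, so the presence of fluorine on the aromatic ring does not by itself sort these compounds, and nothing available here accounts for the gap.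

Going by these compounds, it remains open whether both fluorines of compound 4 are needed, which a phenyl ring bearing a single fluorine would test. Also open, on these data alone, is how this position responds to a ring carrying an amine or a carboxylic acid, and whether the same exchange holds when the rest of the core changes.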